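Adding one fluoro to the phenyl compound

The source may hold more compounds than are shown below. What is called first, only, known or untested is meant among the compounds shown, and "the series" means these compounds.

In a functional assay on LN-229 cells (Homo sapiens) for antiproliferative activity, with a stated time of 72 h (a lower number here means a stronger inhibitor, a higher number a weaker inhibitor), three compounds sharing one core have been measured. Compound 1 `CCCCC#Cc1cc([C@@H]2O[C@H](CO)[C@@H](O)[C@H]2O)n2ncnc(N)c12` gives 1000 nM, compound 2 `Nc1ncnn2c([C@@H]3O[C@H](CO)[C@@H](O)[C@H]3O)cc(C#CC3CC3)c12` gives 30 nM, and compound 3 `Nc1ncnn2c([C@@H]3O[C@H](CO)[C@@H](O)[C@H]3O)cc(-c3ccccc3)c12` gives 75100 nM, the highest number of the three and so the weakest inhibitor. Compound 4 `Nc1ncnn2c([C@@H]3O[C@H](CO)[C@@H](O)[C@H]3O)cc(-c3ccc(F)cc3)c12` departs from compound 3 by one small edit: fluoro in place of hydrogen on an aromatic carbon, which turns phenyl into 4-fluorophenyl.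

Among the measured compounds shown here, no measured step makes this exchange. The closest evidence is a 75-fold higher number from compound 1 to compound 3 (1.88 log units; beyond the scatter) and a 2500-fold higher number from compound 2 to compound 3 (3.40 log units; beyond the scatter), both large, but each swaps a whole group rather than one atom. A smaller edit still gave a 33-fold lower number from compound 1 to compound 2 (1.52 log units; beyond the scatter), so a surprise cannot be ruled out and the range must stay wide. Even so, no step beyond the scatter is expected in this assay. The estimate amounts to a 1.3-fold lower number from compound 3 to compound 4 (0.10 log units; within the scatter), an expected change within the scatter. Compound 4 is estimated at 60000 nM, with an expected range of 15000 nM to 150000 nM.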

Compound 4, half-maximal inhibitory concentration: 65600 nM
Compound 4: middle estimate off by 1.1-fold (0.04 log units), on the low side; the range from low to high includes it.
By their numbers in this assay, from the lowest: compound 2; then compound 1; then compounds 4 and 3 (each within the scatter of the next).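

Placing fluoro on the aromatic carbon para to a large group makes no readable difference in this assay, since a 1.1-fold lower number from compound 3 to compound 4 (0.06 log units; within the scatter) stays within the scatter, so at this spot on the phenyl ring this single-atom exchange leaves the number where it was. The large gap seen for phenyl also remains with the 4-fluorophenyl group, with a 2200-fold higher number from compound 2 to compound 4 (3.34 log units; beyond the scatter) and a 66-fold higher number from compound 1 to compound 4 (1.82 log units; beyond the scatter), so this edit does not bring the compound close to either alkyne compound. No measurement at hand explains either the flat result or these large gaps.

As far as these compounds go, what a bigger group at the same ring carbon would do, such as methoxy, an amine or a carboxylic acid, remains open. So does whether fluoro elsewhere on the phenyl ring would behave the same way.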